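The source may report more compounds than this note shows. Statements on the series, on what has been measured and on what is new or still open speak of the compounds shown alone.

Compound 1 `Cc1nc(S(C)(=O)=O)ccc1Oc1ncnc(OC2CCN(C(=O)SC(C)(C)C)CC2)c1F` gives 76% in a functional assay on isolated protein for inhibition of Glucose-dependent insulinotropic receptor (Rattus norvegicus), read by HTRF and cAMP accumulation; on this read-out higher numbers stand for larger maximal responses and lower numbers for smaller maximal responses.
Compound 2 `Cc1nc(S(C)(=O)=O)ccc1Oc1ncnc(OC2CCN(C(=O)SC3CCC3)CC2)c1F` gives 81% in this assay.

Compound 2 holds the highest of the two numbers, but the gap is small: a number 5 percentage points higher from compound 1 to compound 2 (within the scatter). Compound 3 `Cc1nc(S(C)(=O)=O)ccc1Oc1ncnc(OC2CCN(C(=S)OC3(C)CC3)CC2)c1F` is built from the same atoms as compound 2, joined differently: a group of 7 heavy atoms (5 carbon, 1 oxygen, 1 sulfur; one three-membered non-aromatic ring of carbon only) in place of a group of 7 heavy atoms (5 carbon, 1 oxygen, 1 sulfur; one four-membered non-aromatic ring of carbon only), on an amine nitrogen in a ring. Going by the values given here, the only measured step, cyclobutyl in place of tert-butyl on a sulfur, also altered the group on that ring nitrogen and stayed within the scatter, so no step beyond the scatter is expected here, a number 3 percentage points lower from compound 2 to compound 3 (within the scatter). Compound 3 is therefore estimated at 78%, between 62% and 92%.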

Compound 3, largest response reached (reported as efficacy), in percent of the reference or control that the assay uses: 49%
For compound 3 the middle estimate is 29 percentage points above the measured one; measured number outside the range, below it.
By their numbers in this assay, from the lowest: compound 3; then compounds 1 and 2 (each within the scatter of the next).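

In this assay the group on the amine nitrogen in a ring proves sensitive to a change that keeps the same atoms, with a number 32 percentage points lower from compound 2 to compound 3 (beyond the scatter) and a number 27 percentage points lower from compound 1 to compound 3 (beyond the scatter) while the earlier swap of tert-butyl for cyclobutyl stayed within the scatter. How these atoms are joined therefore matters more at this position than that earlier swap did. Nothing available explains this drop.

Compound 3 alters ring size and the joining of oxygen and sulfur at once, leaving open which of the two carries the drop. Also open, as far as these compounds go, is how a carbamate with oxygen in place of the sulfur would read at this nitrogen.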